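The source may report more compounds than this note shows. Statements on the series, on what has been measured and on what is new or still open speak of the compounds shown alone.

Working notes on the series in an ADME assay on L02 cells (Homo sapiens) for cytotoxicity, read by MTT assay, with a stated time of 72 h; a higher number here means a weaker inhibitor, a lower number a stronger inhibitor. Within the data shown here, compound 1 (`O=C(CCC(=O)OCCCCCCSc1ccc([N+](=O)[O-])c2nonc12)Nc1ccccc1F`) gives 4270 nM, and compound 2 (`Cc1ccccc1NC(=O)CCC(=O)OCCCCCCSc1ccc([N+](=O)[O-])c2nonc12`) gives 9490 nM, the higher of the two numbers so far. Compound 3 (`O=C(CCC(=O)OCCCCCCSc1ccc([N+](=O)[O-])c2nonc12)Nc1ccc(F)cc1`) differs from compound 2 by 4-fluorophenyl in place of 2-methylphenyl on an amide-type nitrogen, with 4-fluorophenyl in place of 2-methylphenyl on an amide-type nitrogen. Among the measured compounds shown here, the only measured step that bears on this is a 2.2-fold higher number from compound 1 to compound 2 (0.35 log units; beyond the scatter), modest and beyond the scatter, and it runs from fluoro to methyl. For the measured compounds named here, the reverse exchange is therefore expected to bring a modest move toward a lower number, although no measured compound carries 4-fluorophenyl. The expected change is a 1.9-fold lower number from compound 2 to compound 3 (0.28 log units; within the scatter). Compound 3 is estimated at 5000 nM, within a range of 2500 nM to 10000 nM.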

Compound 3, half-maximal inhibitory concentration: 6460 nM
Compound 3: the middle estimate sits 1.3-fold (0.11 log units) below what was measured; low and high end bracket the measured number.
By their numbers in this assay, from the lowest: compounds 1, 3 and 2 (each within the scatter of the next, the first and the last beyond it).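

In this assay, the exchange at the amide-type nitrogen gives a 1.5-fold lower number from compound 2 to compound 3 (0.17 log units; within the scatter), and 4-fluorophenyl in place of 2-fluorophenyl gives a 1.5-fold higher number from compound 1 to compound 3 (0.18 log units; within the scatter). 4-Fluorophenyl therefore cannot be told apart from either earlier group, and the step from fluoro to methyl remains the only one at this position beyond the scatter. No data on hand explain these numbers.

Still open, from the compounds shown here alone, is whether 4-methylphenyl would track with 2-methylphenyl or with 4-fluorophenyl. Also open, going by these compounds, is whether a carboxylic acid or an amine on the phenyl ring would move the number beyond the scatter.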